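A few compounds are considered here, and "the series" means these few. Any claim that something is new, unique, unknown or untested is made for them only; others in the source may bear on it.

Of the compounds shown here, two have been measured in a functional assay on PC-12 cells (Rattus norvegicus) for cytotoxicity, read by MTT assay, with stated times of 2 h and 24 h, tested at 1 uM; on this read-out lower numbers stand for a weaker effect and higher numbers for a stronger effect at the one concentration tested. Compound 1 `CCc1ccc(-n2nc(-c3ccc(C(F)(F)F)cc3O)nc2-c2ccccc2O)cc1` gives 64.4% in this assay, and compound 2 `Oc1cc(C(F)(F)F)ccc1-c1nc(-c2ccccc2O)n(-c2ccc(OC(F)(F)F)cc2)n1` gives 65.5%. Among the measured compounds shown here, the single step between them, a number 1.1 percentage points higher from compound 1 to compound 2 (within the scatter), exchanged one group on an aromatic carbon and stayed within the scatter. For the measured compounds named here, compound 2 therefore stands on two numbers only, with compound 1 as its sole neighbour, and the two values are within the scatter of each other, so neither can be ranked over the other. Compound 3 `N#Cc1ccc(-n2nc(-c3ccc(C(F)(F)F)cc3O)nc2-c2ccccc2O)cc1` differs from compound 2 in one place: cyano in place of trifluoromethoxy on an aromatic carbon. Going by the values given here, the one step that bears on this change is a number 1.1 percentage points higher from compound 1 to compound 2 (within the scatter), an exchange at the same aromatic carbon that produced no shift beyond the scatter. On that basis compound 3 is expected to give 64% in this assay, within 50% to 78%, and the step of a number 1.5 percentage points lower from compound 2 to compound 3 (within the scatter) is expected to remain within the scatter.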

Compound 3, a percentage reported as activity, at one concentration (the size of the read-out at that concentration, not a potency): 66.6%
Beside the measured number, compound 3's estimate is 2.6 percentage points below it, within the range that was stated.
By their numbers in this assay, from the lowest: compounds 1, 2 and 3 (each within the scatter of the next).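

In this assay, the aromatic carbon para to a large group now carries a third group: cyano in place of trifluoromethoxy gives a number 1.1 percentage points higher from compound 2 to compound 3 (within the scatter), and cyano in place of ethyl gives a number 2.2 percentage points higher from compound 1 to compound 3 (within the scatter). Among the compounds shown here, the earlier pair showed only one exchange at this carbon, whereas ethyl, trifluoromethoxy and cyano now form a set of three in which no group can be ranked over another, even though cyano brings a triple bond and fewer heavy atoms than trifluoromethoxy. Nothing measured here offers an explanation for this result.

The compounds shown leave open whether any group at this carbon, such as an amine, a carboxylic acid or a longer chain, would give a read-out beyond the scatter. They also leave open whether an exchange elsewhere on the shared core, such as at the trifluoromethyl group, would do so.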